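The compounds below may be only part of what the source reports. "The series", "measured", "known", "first", "only" and "open" are said of these compounds alone.

In an ADME assay on L6 cells (Rattus norvegicus) for cytotoxicity, with a stated time of 72 h (a lower number here means a stronger inhibitor, a higher number a weaker inhibitor), compound 2, whose structure is `CN(C)C12CC(OC(=O)CN3CCCCC3)C(C(c3ccccc3)C1)C(c1ccccc1)C2`, gives 29300 nM. Compound 1, `O=C(CN1CCCCC1)OC1CC2(N3CCCCC3)CC(c3ccccc3)C1C(c1ccccc1)C2`, differs from it by piperidin-1-yl in place of dimethylamino on a saturated ring carbon, and that change gives a 2.1-fold higher number from compound 2 to compound 1 (0.31 log units; beyond the scatter). Compound 3, `CN(C)C12CC(O)C(C(c3ccccc3)C1)C(c1ccccc1)C2`, differs from compound 2 by hydrogen in place of ((piperidin-1-yl)methyl)carbonyl on an oxygen on a saturated carbon, which gives a 4.5-fold higher number from compound 2 to compound 3 (0.66 log units; beyond the scatter); in this assay compound 3 gives 133000 nM, while compound 1 gives 60400 nM.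

Compound 4, `OC1CC2(N3CCCCC3)CC(c3ccccc3)C1C(c1ccccc1)C2`, has not yet been measured. It differs from compound 3 by piperidin-1-yl in place of dimethylamino on a saturated ring carbon. This is the same kind of change as from compound 2 to compound 1, on a carbon that in compound 3 sits two ring bonds from the ring atom that bears a hydroxy group rather than a (((piperidin-1-yl)methyl)carbonyl)oxy group. Because that earlier change gave a 2.1-fold higher number from compound 2 to compound 1 (0.31 log units; beyond the scatter), a step of similar size is expected here, a 2.1-fold higher number from compound 3 to compound 4 (0.32 log units; beyond the scatter). Among the compounds with values here, on this basis compound 4 is estimated at 280000 nM, most likely between 130000 nM and 600000 nM, although with only one earlier example this rests on thin ground.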

Compound 4, half-maximal inhibitory concentration: 37300 nM
Estimate against measurement, compound 4: 7.5-fold (0.88 log units) above, and the stated range ends above it.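

In this assay, piperidin-1-yl in place of dimethylamino gives a 3.6-fold lower number from compound 3 to compound 4 (0.55 log units; beyond the scatter), so this swap does not carry over unchanged from one core to the other: the same change on two cores in this assay, a 2.1-fold higher number (0.31 log units; beyond the scatter) from compound 2 to compound 1 and a 3.6-fold lower number (0.55 log units; beyond the scatter) from compound 3 to compound 4, 7.4-fold (0.87 log units) apart, beyond the scatter of two such steps. Hydrogen in place of ((piperidin-1-yl)methyl)carbonyl on the oxygen gives a 1.6-fold lower number from compound 1 to compound 4 (0.21 log units; within the scatter), so the effect of this second change also depends on the core it is made on: the same change on two cores in this assay, a 4.5-fold higher number (0.66 log units; beyond the scatter) from compound 2 to compound 3 and a 1.6-fold lower number (0.21 log units; within the scatter) from compound 1 to compound 4, 7.4-fold (0.87 log units) apart, beyond the scatter of two such steps. Both gaps come from the same four compounds, so they are one observation seen from two sides: the two changes do not act independently here, but these data do not show why, or whether this holds beyond these compounds.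

As far as these compounds go, it remains open whether another amine on that saturated ring carbon, such as pyrrolidin-1-yl or morpholin-4-yl, would behave like dimethylamino or like piperidin-1-yl on each core. From the compounds shown here alone, it is also open how a longer chain between the carbonyl and the piperidine ring would affect the size of these steps.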